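The compounds below may be only part of what the source reports. "The series", "measured", "known", "first", "only" and "open" are said of these compounds alone.

Measured compounds:
Compound 1, `C#CC(C)OC(=O)c1ccc(C(CC)(CC)c2ccc(OCCC(O)(CC)CC)c(C)c2)n1CC`: > 50000 nM
Compound 2, `CCOC(=O)C(CC(=O)OC)NC(=O)c1ccc(C(CC)(CC)c2ccc(OCCC(O)(CC)CC)c(C)c2)n1CC`: 4280 nM

In an ADME assay on L02 cells (Homo sapiens) for antiproliferative activity, read by MTT assay, with a stated time of 48 h (on this read-out higher numbers stand for weaker inhibition and lower numbers for stronger inhibition), compound 1 gives > 50000 nM; this is a limit of the assay, not a number, so compound 1 stands at the limit of > 50000 nM in this assay, at which 1 of the 2 values shown sits, and nothing more is known of it. Compound 2 gives 4280 nM. Among the measured compounds shown here, the only measured step, an at least 11-fold lower number from compound 1 to compound 2 (1.06 log units; beyond the scatter), exchanged the ester-linked group on the carbonyl carbon for an amide-linked one and brought the number down strongly.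

Compound 3, `CCn1c(C(=O)NC(C)CO)ccc1C(CC)(CC)c1ccc(OCCC(O)(CC)CC)c(C)c1`, has not yet been measured here. It differs from compound 1 by (1-(hydroxymethyl)ethyl)amino in place of (1-methylprop-2-yn-1-yl)oxy on a carbonyl carbon, again an amide-linked group on the carbonyl carbon in place of the ester-linked one. Because the step of an at least 11-fold lower number from compound 1 to compound 2 (1.06 log units; beyond the scatter) went in that direction, compound 3 is expected to give a lower number than compound 1, an at least 3.3-fold lower number from compound 1 to compound 3 (0.52 log units; beyond the scatter), though the size is uncertain since compound 1 is only a limit. Compound 3 is estimated at 15000 nM, between 4000 nM and 50000 nM.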

Compound 3, half-maximal inhibitory concentration: 4840 nM
Estimate against measurement, compound 3: 3.1-fold (0.49 log units) above; the measured number falls inside the stated range.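

In this assay, (1-(hydroxymethyl)ethyl)amino in place of (1-methylprop-2-yn-1-yl)oxy on a carbonyl carbon gives an at least 10-fold lower number from compound 1 to compound 3 (1.01 log units; beyond the scatter), so a second amide-linked group goes the same way as the first. Compound 1 is a limit of the assay and not a number: the limit of > 50000 nM in this assay, at which 1 of the 3 values shown sits. The two amides themselves do not separate, for the exchange on the amide-type nitrogen gives a 1.1-fold higher number from compound 2 to compound 3 (0.05 log units; within the scatter), and the larger group of compound 2 therefore shows no difference from the smaller group of compound 3 on this read-out.

The compounds shown leave open whether the drop belongs to the amide link itself or to the groups it carries. Also open, as far as these compounds go, is how a carboxylic acid or a dimethylamino group on the same carbonyl carbon would read in this assay.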